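The source may hold more compounds than are shown below. What is called first, only, known or untested is meant among the compounds shown, and "the series" means these compounds.

Two compounds share one core and differ only in a substituent on the phenyl ring of the tetrazole. Compound 1 `CCCCCCCCc1ccc(OC(C)C(=O)Cn2nnc(-c3ccccc3)n2)cc1` gives 24 nM in an assay on microsomes from brain for inhibition of Fatty-acid amide hydrolase 1 (Rattus norvegicus), read by fluorescence and HPLC, with a stated time of 60 min; on this read-out lower numbers stand for stronger inhibition and higher numbers for weaker inhibition. Compound 2 `CCCCCCCCc1ccc(OC(C)C(=O)Cn2nnc(-c3ccc(Cl)cc3)n2)cc1`, which carries a chloro on that ring, gives 35 nM in this assay; on the two numbers shown it stands at the highest, with compound 1 as its nearest neighbour, and the step of a 1.5-fold higher number from compound 1 to compound 2 (0.16 log units; within the scatter) lies within the scatter.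

Compound 3 `CCCCCCCCc1ccc(OC(C)C(=O)Cn2nnc(-c3ccc(C(=O)OC)cc3)n2)cc1` differs from compound 2 by methoxycarbonyl in place of chloro on an aromatic carbon. Going by the values given here, the only measured step that bears on this position is a 1.5-fold higher number from compound 1 to compound 2 (0.16 log units; within the scatter), which was small, so the change to methoxycarbonyl is expected to move the number little, with at most a modest drift upward: the step of a 1.4-fold higher number from compound 2 to compound 3 (0.15 log units; within the scatter) is what is expected. Compound 3 is therefore estimated at 50 nM, within a range from 15 nM to 160 nM.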

Compound 3, half-maximal inhibitory concentration: 25 nM
Beside the measured number, compound 3's estimate is 2.0-fold (0.30 log units) above it; the range from low to high includes it.
By their numbers in this assay, from the lowest: compounds 1, 3 and 2 (each within the scatter of the next).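

In this assay, the step from chloro to methoxycarbonyl is a 1.4-fold lower number from compound 2 to compound 3 (0.15 log units; within the scatter), and the step from hydrogen to methoxycarbonyl is a 1.0-fold higher number from compound 1 to compound 3 (0.02 log units; within the scatter). The earlier compounds shown here showed only that a single atom, chloro, could stand on this aromatic carbon. Methoxycarbonyl, with 4 heavy atoms and 2 hydrogen-bond acceptors where chloro has none, now shows that a much larger group can stand there too, with all three compounds within the scatter of one another in this assay, and nothing available here explains this tolerance.

On these data alone, whether it extends to an amine, a carboxylic acid or a longer chain at this position remains open. The compounds shown also leave open whether the same groups would read alike elsewhere on this six-membered aromatic ring.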